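This account rests on a few compounds, and the source may have more. Where it says the series, first, only, none or still open, it means among the compounds named here.

Measured compounds in a toxicity assay on MDCK cells (Canis lupus familiaris) for cytotoxicity, read by crystal violet staining, with a stated time of 48 h; on this read-out lower numbers stand for higher toxicity in this test and higher numbers for lower toxicity in this test:

Compound 1, `Cc1ccc2cc(CN(Cc3ccc(C(C)C)cc3)Cc3ccccc3F)c(=O)[nH]c2c1` — compound 1 gives > 33000 nM, a limit of the assay.
Compound 2, `CCc1ccc(CN(Cc2ccc(F)cc2)Cc2cc3ccc(C)cc3[nH]c2=O)cc1` — compound 2 gives > 33000 nM, a limit of the assay.
Compound 3, `Cc1ccc2[nH]c(=O)c(CN(Cc3ccccc3)Cc3ccc(C(C)(C)C)cc3)cc2c1` — compound 3 gives > 5000 nM, a limit of the assay.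

None of the three compounds gives a number in this assay; each result is a limit. Two of them sit at the limit of > 33000 nM in this assay, at which 2 of the 3 values shown sit, and one at the limit of > 5000 nM in this assay, at which 1 of the 3 values shown sits. Compound 3 therefore stands where its result is a limit, and the two other results shown are limits as well, so no order among the three can be read from these values and no step between measured compounds is available.

The step under consideration goes from compound 3 to compound 4, `COc1ccc(C(C)N(Cc2ccc(C(C)(C)C)cc2)Cc2cc3cc(C)ccc3[nH]c2=O)cc1`. The change is 1-(4-methoxyphenyl)ethyl in place of benzyl on an amine nitrogen. Among the compounds with values here, no measured step shows what this kind of change does in this assay.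

With every measured value a limit, the expectation is that compound 4 is also no more toxic than the scatter would show, and that this assay for compound 4 most likely reports a limit again rather than a number. The estimate for compound 4 is 20000 nM, within 5000 nM to 60000 nM. This corresponds to an expected step that the limit leaves unreadable from compound 3 to compound 4, which is meant as no change beyond the scatter.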

Compound 4, half-maximal cytotoxic concentration: > 5000 nM
Compound 4 gave a limit, no number; the forecaster's own chance of this, stated with the estimate: 70%; the middle value does not contradict the limit.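

In this assay, compound 3 and compound 4 both give a limit rather than a number, so no step between them can be read: the limit of > 5000 nM in this assay, at which 2 of the 4 values shown sit.

The compounds shown leave open whether 1-(4-methoxyphenyl)ethyl in place of benzyl on an amine nitrogen changes the half-maximal cytotoxic concentration, and at what concentration any of the four compounds would reach it.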